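The source may hold more compounds than are shown below. What is called first, only, known or untested is meant among the compounds shown, and "the series" means these compounds.

Of the compounds shown here, three with the same core have been measured in an ADME assay on microsomes from liver (Homo sapiens) for pharmacokinetics, read by LC-MS, with a stated time of 60 min, tested at 1 uM (a lower number here means slower removal, a higher number faster removal of the compound), and they differ only in the group on a sulfonyl sulfur. Compound 1 (`O=C(NCc1ccc(S(=O)(=O)c2cc(F)cc(F)c2)cc1)N1Cc2ccncc2C1`) gives 8 mL/min/kg, and compound 2 (`CCCn1cc(S(=O)(=O)c2ccc(CNC(=O)N3Cc4ccncc4C3)cc2)cn1`) gives 11 mL/min/kg. Compound 3 (`O=C(NCc1ccc(S(=O)(=O)C2CCN(C3COC3)CC2)cc1)N1Cc2ccncc2C1`) gives 10 mL/min/kg, which lies within the scatter of both other values. Compound 4 (`O=C(NCc1ccc(S(=O)(=O)N2CCOCC2)cc1)N1Cc2ccncc2C1`) has not yet been measured. It departs from compound 3 in one place, on a sulfonyl sulfur whose other neighbour is an aromatic carbon: morpholin-4-yl in place of 1-(oxetan-3-yl)piperidin-4-yl on a sulfonyl sulfur. Three measured steps change the group at this same place. They are a 1.3-fold higher number from compound 1 to compound 3 (0.10 log units; within the scatter), a 1.1-fold lower number from compound 2 to compound 3 (0.04 log units; within the scatter) and a 1.4-fold higher number from compound 1 to compound 2 (0.14 log units; within the scatter). All three stay within the scatter in this assay, even though 3,5-difluorophenyl, 1-propyl-1H-pyrazol-4-yl and 1-(oxetan-3-yl)piperidin-4-yl are quite different groups. Going by the values given here, none of the measured compounds carries morpholin-4-yl, however, so these steps offer only indirect guidance. On that basis, no step beyond the scatter is expected, and no direction can be favoured. The expected step is no change at the digits printed from compound 3 to compound 4 (within the scatter). The estimated value for compound 4 is 10 mL/min/kg, with an expected range from 5 mL/min/kg to 19 mL/min/kg.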

Compound 4, clearance: 9 mL/min/kg
Compound 4: middle estimate off by 1.1-fold (0.05 log units), on the high side, within the range that was stated.
By their numbers in this assay, from the lowest: compounds 1, 4, 3 and 2 (each within the scatter of the next).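

In this assay, the steps of a 1.1-fold lower number from compound 3 to compound 4 (0.05 log units; within the scatter) and a 1.2-fold lower number from compound 2 to compound 4 (0.09 log units; within the scatter) and a 1.1-fold higher number from compound 1 to compound 4 (0.05 log units; within the scatter) all stay within the scatter, so this position tolerates morpholin-4-yl as well as the three earlier groups. Going by these compounds alone, this adds two things the earlier compounds could not show: morpholin-4-yl is the first group here held to the sulfonyl sulfur through a ring nitrogen rather than a carbon, and going from 1-(oxetan-3-yl)piperidin-4-yl to morpholin-4-yl takes the group from 10 heavy atoms to 6 and removes the four-membered ring, yet neither change carries the number beyond the scatter. Nothing measured here explains why this position shows so little response.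

All four groups shown contain a ring, so it remains open whether an open-chain group such as diethylamino, a longer alkyl chain, or a group bearing a carboxylic acid or a primary amine on the sulfonyl sulfur would also stay within the scatter. The compounds shown also leave open whether any change on the shared core, away from this sulfonyl sulfur, would move the number further than these steps do.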